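A few compounds are considered here, and "the series" means these few. Any claim that something is new, unique, unknown or untested is made for them only; others in the source may bear on it.

For the measured compounds named here, compound 1 `N=C(NO)N/N=C/c1ccccc1Cl` is the only compound here with a definite number in a functional assay on HL-60 cells (Homo sapiens) for antiproliferative activity (on this read-out lower numbers stand for stronger inhibition and higher numbers for weaker inhibition), where compound 1 gives 60000 nM. Compound 2 `COc1ccccc1/C=N/N=C(\N)NO` reaches only a limit of the assay, giving in this assay a value of > 100000 nM; this is the case summarised as the limit of > 100000 nM in this assay, at which 1 of the 2 values shown sits. Compound 3 `Cc1ccccc1/C=N/NC(=N)NO` differs from compound 1 by methyl in place of chloro on an aromatic carbon. Going by the values given here, no such step has been measured. In this assay the expected step is a 1.3-fold higher number from compound 1 to compound 3 (0.12 log units; within the scatter), small and, if anything, toward weaker inhibition. Compound 3 is expected to give about 80000 nM, within 30000 nM to 200000 nM.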

Compound 3, half-maximal inhibitory concentration: > 100000 nM
Compound 3 was reported as a limit; the forecaster's own chance of this, stated with the estimate: 40%; at least 1.2-fold (0.09 log units) between middle value and limit.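

In this assay, methyl in place of chloro on an aromatic carbon is the first one-place step shown at this position, and it gives an at least 1.6-fold higher number from compound 1 to compound 3 (0.22 log units; that floor lies within the scatter). From the compounds shown here alone, the value of compound 3 is a limit and not a number, which makes this step only a floor: a real loss on leaving chloro is neither established nor excluded, and its true size stays unknown. Readings at this position now run into the end of the range: the limit of > 100000 nM in this assay, at which 2 of the 3 values shown sit.

The compounds shown leave open whether bromo, trifluoromethyl or an amine on this aromatic carbon would give a definite number in this assay.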